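A few compounds are considered here, and "the series" means these few. Any claim that something is new, unique, unknown or untested is made for them only; others in the source may bear on it.

Measured in an ADME assay on HOS cells (Homo sapiens) for cytotoxicity; a lower number here means that less compound is tolerated, a higher number that more compound is tolerated:
- compound 1 `CN1CCN(c2cccc3nc(CN(C)[C@H]4CCCc5cccnc54)cn23)CC1`: 4500 nM
- compound 2 `CNCCN(C)c1cccc2nc(CN(C)[C@H]3CCCc4cccnc43)cn12`: 2200 nM
- compound 3 `CC(C)N1CCN(c2cccc3nc(CN(C)[C@H]4CCCc5cccnc54)cn23)CC1`: 7100 nM

These three compounds share one core and differ only in the amine group attached to it. Compound 3, at 7100 nM, cannot be told apart from compound 1, with a 1.6-fold higher number from compound 1 to compound 3 (0.20 log units; within the scatter). It does stand clear of compound 2, with a 3.2-fold higher number from compound 2 to compound 3 (0.51 log units; beyond the scatter).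

The next compound to be tested is compound 4 `CN(C)C1CCN(c2cccc3nc(CN(C)[C@H]4CCCc5cccnc54)cn23)CC1`. Its change from compound 3 is 4-(dimethylamino)piperidin-1-yl in place of 4-isopropylpiperazin-1-yl on an aromatic carbon. In words, 4-(dimethylamino)piperidin-1-yl comes in place of 4-isopropylpiperazin-1-yl on an aromatic carbon, and the two compounds have the same atoms, joined differently.

Among the measured compounds shown here, no measured step makes this exact swap, so the evidence is indirect. Changing the group on the ring nitrogen gave only a 1.6-fold higher number from compound 1 to compound 3 (0.20 log units; within the scatter). The largest change in the set, replacing the ring of compound 1 with an open chain, gave no more than a 2.0-fold lower number from compound 1 to compound 2 (0.31 log units; beyond the scatter). All three values therefore lie close together in this assay, and a large move would be a surprise.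

The expected step is small, a 1.6-fold lower number from compound 3 to compound 4 (0.20 log units; within the scatter), and no shift beyond the scatter is expected. The estimated value for compound 4 is 4500 nM, with an expected range of 2000 nM to 10000 nM.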

Compound 4, half-maximal cytotoxic concentration: 3400 nM
For compound 4 the middle estimate is 1.3-fold (0.12 log units) above the measured one, within the range that was stated.
By their numbers in this assay, from the lowest: compounds 2, 4, 1 and 3 (each within the scatter of the next, the first and the last beyond it).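

In this assay, among the compounds shown here, this change keeps the same atoms in the group but rearranges them, so that its ring holds one hetero atom instead of two and the second nitrogen sits outside the ring as dimethylamino; the earlier compounds did not show such a rearrangement, and here it gives a step beyond the scatter, a 2.1-fold lower number from compound 3 to compound 4 (0.32 log units; beyond the scatter). Against the other two compounds there is no clear difference, with a 1.3-fold lower number from compound 1 to compound 4 (0.12 log units; within the scatter) and a 1.5-fold higher number from compound 2 to compound 4 (0.19 log units; within the scatter). Compound 4 therefore lies within the scatter of both compound 1 and compound 2, even though those two lie beyond the scatter of each other, and among the four compounds this position has so far shown only modest steps, whether the group is a piperazine, a piperidine or an open chain.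

Nothing measured here gives a reason for these differences. On these data alone, it remains open whether a morpholin-4-yl group, with an oxygen in the ring in place of the second nitrogen, or a piperidin-1-yl group with no second nitrogen at all, would stay in this same narrow band in this assay.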